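A Difluorophenyl Variant of a Trimethoxyphenyl Pyrazole Chalcone

The source may hold more compounds than are shown below. What is called first, only, known or untested is meant among the compounds shown, and "the series" means these compounds.

Compound 1 `COc1cc(-c2cc(/C=C/C(=O)c3ccc(N)cc3)[nH]n2)cc(OC)c1OC` carries a 4-aminophenyl on its carbonyl carbon. In a functional assay on A498 cells (Homo sapiens) for cytotoxicity, read by sulforhodamine B assay, with a stated time of 48 h, tested at 100 uM (on this read-out higher numbers stand for a weaker effect at the one concentration tested and lower numbers for a stronger effect), compound 1 gives -96%. Its closest measured neighbour is compound 2 `COc1ccc(C(=O)/C=C/c2cc(-c3cc(OC)c(OC)c(OC)c3)n[nH]2)cc1OC`, which carries a 3,4-dimethoxyphenyl at the same place and in this assay gives -96%. The step of no change at the digits printed from compound 1 to compound 2 (within the scatter) shows that exchanging the aryl group on the carbonyl carbon, at the concentration tested, left the read-out where it was, so compound 1 stands level with compound 2 and neither can be called the stronger of the two.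

Compound 3 `COc1cc(-c2cc(/C=C/C(=O)c3ccc(F)c(F)c3)[nH]n2)cc(OC)c1OC` differs from compound 1 as follows: 3,4-difluorophenyl in place of 4-aminophenyl on a carbonyl carbon. Going by the values given here, the only measured step that bears on this change is the one from compound 1 to compound 2, which altered the same aryl group on the carbonyl carbon and stayed within the scatter. Compound 3 is therefore expected to sit close to compound 1, with a step of a number 2 percentage points higher from compound 1 to compound 3 (within the scatter) that does not exceed the scatter, and its estimated value in this assay is -94%, with a range from -100% to -78%.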

Compound 3, a percentage reported as activity, at one concentration (the size of the read-out at that concentration, not a potency): -40%
For compound 3 the middle estimate is 54 percentage points below the measured one; measured number above the stated range.
By their numbers in this assay, from the lowest: compounds 1 and 2 (each within the scatter of the next); then compound 3.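

The aryl group on the carbonyl carbon is not as indifferent as the earlier pair suggested: in this assay, the 3,4-difluorophenyl gives a number 56 percentage points higher from compound 1 to compound 3 (beyond the scatter) and, against the 3,4-dimethoxyphenyl, a number 56 percentage points higher from compound 2 to compound 3 (beyond the scatter), both toward a weaker effect at the one concentration tested. Going by these compounds alone, the level reading of compound 1 and compound 2 therefore held for those two groups only and does not extend to every aryl group at this place, since the core of compound 1 stays the same in compound 3 and only this group changes, with the nitrogen of the 4-aminophenyl leaving and two fluorine atoms entering. Nothing given here accounts for the size of this step.

The compounds shown leave open whether the weaker effect of compound 3 needs both fluorine atoms or would also appear with a 4-fluorophenyl, and whether a 4-chlorophenyl or a 4-hydroxyphenyl on the carbonyl carbon would read with compound 1 or with compound 3. Because each compound was read at a single concentration, these values also leave open how the three compare in potency.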